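This account rests on a few compounds, and the source may have more. Where it says the series, first, only, none or still open, it means among the compounds named here.

Working notes on the series.

Compound 1, `CCCc1nc(CC)c(C(=O)OCc2ccccc2C(=O)c2ccccc2)n1Cc1ccc(-c2ccccc2S(=O)(=O)NC(=O)OCCc2ccccc2)cc1F`, gives 0.69 nM in an assay on isolated protein for binding affinity to Type-2 angiotensin II receptor (Homo sapiens); a lower number here means a stronger inhibitor, a higher number a weaker inhibitor. Among the three numbers measured so far it sits at the low end, yet neither neighbour is separated from it by more than the scatter: a 1.4-fold higher number from compound 1 to compound 2 (0.16 log units; within the scatter), and a 1.3-fold higher number from compound 1 to compound 3 (0.12 log units; within the scatter). Compound 2 is `CCCc1nc(CC)c(C(=O)OCc2ccccc2C(=O)c2ccccc2)n1Cc1ccc(-c2ccccc2S(=O)(=O)NC(=O)OCC(C)C)cc1F` and gives 1 nM in this assay; compound 3 is `CCCCOC(=O)NS(=O)(=O)c1ccccc1-c1ccc(Cn2c(CCC)nc(CC)c2C(=O)OCc2ccccc2C(=O)c2ccccc2)c(F)c1` and gives 0.9 nM. Between those two, a 1.1-fold lower number from compound 2 to compound 3 (0.05 log units; within the scatter). All three measured steps alter only the chain on the carbamate oxygen, and none of them moves the number beyond the scatter.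

Compound 4, `CCCc1nc(CC)c(C(=O)OCc2ccccc2C(=O)c2ccccc2)n1Cc1ccc(-c2ccccc2S(=O)(=O)NC(=O)OCCc2ccccc2)cc1`, differs from compound 1 by hydrogen in place of fluoro on an aromatic carbon, the site being ortho to a large group and meta to a large group. Within the data shown here, no measured step touches this aromatic carbon, so the steps above give no direct guide; what they do show is that the shared core, with the carbamate region varied, holds within a narrow band of this assay. On that basis a step of no more than the scatter is expected, with a small drift toward a higher number left open. Compound 4 is therefore estimated at 1.1 nM, within 0.45 nM to 2.8 nM, which corresponds to an expected step of a 1.6-fold higher number from compound 1 to compound 4 (0.20 log units; within the scatter).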

Compound 4, half-maximal inhibitory concentration: 2.1 nM
The estimate for compound 4 lay 1.9-fold (0.28 log units) below the measured number, within the range that was stated.
By their numbers in this assay, from the lowest: compounds 1, 3 and 2 (each within the scatter of the next); then compound 4.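

Among these compounds, the aromatic carbon ortho to a large group and meta to a large group is the first place where a single change carries the number in this assay beyond the scatter: with hydrogen in place of fluoro, there is a 3.0-fold higher number from compound 1 to compound 4 (0.48 log units; beyond the scatter), whereas every step on the carbamate chain stayed within it. The narrow band seen while that chain was varied therefore does not extend to this aromatic carbon, and the departure of a single fluorine atom, with no ring, hydrogen-bond donor, hydrogen-bond acceptor or net charge changing, is enough for a step of modest size with the rest of compound 1 held fixed. Nothing at hand bears on why this step occurs.

From the compounds shown here alone, whether the same change gives a step of similar size with the carbamate chains of compound 2 and compound 3 remains open, since this aromatic carbon is compared on the chain of compound 1 alone. Also open, going by these compounds, is how chloro, methyl or methoxy on this aromatic carbon would stand against fluoro and hydrogen in this assay, so the two groups compared here do not yet define a trend at this site.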